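Three Diaryl Pyridazines and a Sulfone Yet to Be Tested

The compounds below may be only part of what the source reports. "The series", "measured", "known", "first", "only" and "open" are said of these compounds alone.

Of the compounds shown here, three built on a shared core have been measured in an assay on microsomes from liver for inhibition of sterol O-acyltransferase 1 (Rattus norvegicus); on this read-out higher numbers stand for weaker inhibition and lower numbers for stronger inhibition. Compound 1 `CCCCCCOc1cc(-c2ccccc2)c(-c2ccccc2)nn1` gives 72000 nM. Compound 2 `CCCCCCCOc1cc(-c2ccccc2)c(-c2ccccc2)nn1` gives 58000 nM. Within the data shown here, compound 3 `CCCCCCSc1cc(-c2ccccc2)c(-c2ccccc2)nn1` gives 62000 nM, which puts compound 3 second highest among the three numbers, with all three close together: the step of a 1.2-fold lower number from compound 1 to compound 2 (0.09 log units; within the scatter) and the step of a 1.2-fold lower number from compound 1 to compound 3 (0.06 log units; within the scatter) are both small, as is the step of a 1.1-fold higher number from compound 2 to compound 3 (0.03 log units; within the scatter), so no compound can be singled out.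

Compound 4 `CCCCCCS(=O)(=O)c1cc(-c2ccccc2)c(-c2ccccc2)nn1` has not been measured. It differs from compound 3 in one place: hexylsulfonyl in place of hexylsulfanyl on an aromatic carbon.

Among the measured compounds shown here, none of the measured steps involves an oxidation of this kind. The nearest comparison is the exchange of oxygen for sulfur in the step of a 1.2-fold lower number from compound 1 to compound 3 (0.06 log units; within the scatter), which stayed within the scatter, yet that is a different change. For the measured compounds named here, with no direct precedent, the expected step of a 1.3-fold higher number from compound 3 to compound 4 (0.11 log units; within the scatter) in this assay is set near zero but with a wide range. Compound 4 is therefore estimated at 80000 nM, likely between 20000 nM and 320000 nM.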

Compound 4, half-maximal inhibitory concentration: 60000 nM
The estimate for compound 4 lay 1.3-fold (0.12 log units) above the measured number, and the stated range covers the measured number.
By their numbers in this assay, from the lowest: compounds 2, 4, 3 and 1 (each within the scatter of the next).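

In this assay, hexylsulfonyl in place of hexylsulfanyl on the aromatic carbon next to the ring nitrogen gives a 1.0-fold lower number from compound 3 to compound 4 (0.01 log units; within the scatter), so this change at this position leaves the number within the scatter. The comparisons with the oxygen-linked chains read the same way, with a 1.0-fold higher number from compound 2 to compound 4 (0.01 log units; within the scatter) and a 1.2-fold lower number from compound 1 to compound 4 (0.08 log units; within the scatter), and so all four groups at this carbon remain indistinguishable in this read-out. No further data bear on why these groups give such similar numbers.

From the compounds shown here alone, it remains open whether any group at this carbon can move the number beyond the scatter, such as an amine, a carboxylic acid or a much longer chain. The phenyl groups are the same in all four compounds, so what they contribute cannot be told.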